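This account rests on a few compounds, and the source may have more. Where it says the series, first, only, none or still open, it means among the compounds named here.

Measured so far in an ADME assay on Vero cells (Chlorocebus sabaeus) for inhibition, read by sulforhodamine B assay, with a stated time of 48 h; on this read-out higher numbers stand for weaker inhibition of growth and lower numbers for stronger inhibition of growth:
Compound 1 `CC1=CC[C@H](C(C)(C)NC(=S)N/N=C/c2ccccc2O)CC1` gives 3100 nM.
Compound 2 `CC1=CC[C@H](C(C)(C)NC(=S)N/N=C(\C)c2ccccc2)CC1` gives > 100000 nM, which is a limit of the assay and not a number.
Compound 3 `COc1ccc(/C(C)=N/NC(=S)NC(C)(C)[C@H]2CC=C(C)CC2)cc1` gives > 100000 nM, which likewise is a limit of the assay.

Compound 3 therefore stands at the limit of > 100000 nM in this assay, at which 2 of the 3 values shown sit, and no number for it is known. Compound 1 is the only one of the three that gives a number in this assay. Going by the values given here, the one measured step that reaches compound 3, a step that the two limits leave unreadable from compound 2 to compound 3, runs between two limits, so its size cannot be read.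

Compound 4 `CC1=CC[C@H](C(C)(C)NC(=S)N/N=C(\C)c2ccc([N+](=O)[O-])cc2)CC1` differs from compound 3 by nitro in place of methoxy on an aromatic carbon. Among the compounds with values here, the only measured step that touches the same place is the step from compound 2 to compound 3 a step that the two limits leave unreadable from compound 2 to compound 3, and because that step is a step that the two limits leave unreadable from compound 2 to compound 3 it offers no size to carry forward. Within the data shown here, no measured step introduces a nitro group anywhere in this set.

With compound 3 itself sitting at a limit, the change to compound 4 is expected to leave the value at the limit as well, and the expected step is a number no higher from compound 3 to compound 4 (the limit leaves the size open), none beyond the scatter. Compound 4 is accordingly estimated at 100000 nM in this assay, with a range from 30000 nM to 300000 nM.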

Compound 4, concentration for 50% growth inhibition: 67100 nM
For compound 4 the middle estimate is 1.5-fold (0.17 log units) above the measured one; the range from low to high includes it.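

Among the compounds that share the core of compound 2, compound 4 alone gives a number in this assay, so this place on the aromatic ring, para to a large group, is now seen to allow a measurable inhibition of growth. Nitro in place of methoxy gives an at least 1.4-fold lower number from compound 3 to compound 4 (0.17 log units; that floor lies within the scatter), and nitro in place of hydrogen gives an at least 1.4-fold lower number from compound 2 to compound 4 (0.17 log units; that floor lies within the scatter). These two steps are floors and not full sizes, and each starts from a compound that sits at a limit of the assay and has no number: the limit of > 100000 nM in this assay, at which 2 of the 4 values shown sit.

The compounds shown leave open how large either step really is, and whether another group at this place, such as an amine, a nitrile or a carboxylic acid, would also give a number or would return the value to the limit. They also leave open how the number of compound 4 relates to that of compound 1, which differs from it in more than one place, so no single change can be read from that pair.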